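A Carboxylic Acid Replaces an Ester on the Shared Core

The compounds below may be only part of what the source reports. "The series", "measured", "known", "first", "only" and "open" are said of these compounds alone.

Compound 3 `COC(=O)c1ccccc1-c1ccc(CSc2nc(C(C)C)nc3ccccc23)cc1` carries a 2-(methoxycarbonyl)phenyl group on the benzyl arm of the shared core. In an assay on isolated protein for inhibition of phosphodiesterase 7 (Homo sapiens), read by scintillation proximity assay and cAMP accumulation, with a stated time of 1 h (a lower number here means a stronger inhibitor, a higher number a weaker inhibitor), compound 3 gives > 100000 nM, which is a limit of the assay and not a number. Compound 1 `Cc1nc(SCc2ccc(-c3ccccc3C#N)cc2)c2ccccc2n1` in this assay gives > 100000 nM, again only a limit. Compound 2 `N#Cc1ccccc1-c1ccc(CSc2nc(C(Cl)(Cl)Cl)nc3ccccc23)cc1` in this assay gives > 100000 nM, also a limit. Among the measured compounds shown here, the single measured step between neighbours, a step that the two limits leave unreadable from compound 1 to compound 2, therefore cannot be sized, and the whole picture is summed up by the limit of > 100000 nM in this assay, at which 3 of the 3 values shown sit.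

Compound 4 `CC(C)c1nc(SCc2ccc(-c3ccc(C(=O)O)cc3)cc2)c2ccccc2n1` has not yet been measured. It differs from compound 3 in one place: 4-carboxyphenyl in place of 2-(methoxycarbonyl)phenyl on an aromatic carbon. For the measured compounds named here, none of the measured steps concerns this kind of change, and the one step that exists is unreadable, so nothing measured points in either direction. Compound 4 is expected to give about 100000 nM in this assay, within a range from 20000 nM to 300000 nM, most probably reported again as a limit rather than a number. The step that this estimate means, a number no higher from compound 3 to compound 4 (the limit leaves the size open), is expected to be none beyond the scatter.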

Compound 4, half-maximal inhibitory concentration: 930 nM
The estimate for compound 4 lay 110-fold (2.03 log units) above the measured number, and the stated range ends above it.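

Among the compounds shown here, replacing 2-(methoxycarbonyl)phenyl with 4-carboxyphenyl gives an at least 100-fold lower number from compound 3 to compound 4 (2.03 log units; beyond the scatter) in this assay, the first step whose size can be read. For the compounds shown here, it shows that the aryl group on the benzyl arm of the shared core can move the result away from the assay limit, which the earlier compounds could not show, and compound 4 alone has a number rather than a limit: the limit of > 100000 nM in this assay, at which 3 of the 4 values shown sit. The step changes two things at once, since the ester gives way to a carboxylic acid and the number in the group's name changes from 2 to 4, so it cannot assign the gain to either change alone.

The compounds shown leave open how 2-carboxyphenyl and 4-(methoxycarbonyl)phenyl would compare, and these are the two groups that would separate the acid from its place on the ring. They also leave open whether an amide, a tetrazole or a carboxylic acid on a longer chain would keep the gain, and whether it would survive replacing the isopropyl group with methyl or trichloromethyl.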